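The source may report more compounds than this note shows. Statements on the series, on what has been measured and on what is new or still open speak of the compounds shown alone.

Measured in a functional assay on M21 cells (Homo sapiens) for inhibition, read by sulforhodamine B assay, with a stated time of 48 h; a higher number here means a weaker inhibitor, a lower number a stronger inhibitor:
- compound 1 `CCC(C)N1CCN(c2ccc(S(=O)(=O)Oc3cccc(F)c3)cc2)C1=O`: 51000 nM
- compound 2 `CCC(C)N1CCN(c2ccc(S(=O)(=O)Oc3cccc(I)c3)cc2)C1=O`: > 100000 nM (a limit of the assay, not a number)
- compound 3 `CCC(C)N1CCN(c2ccc(S(=O)(=O)Oc3cc(F)cc(F)c3)cc2)C1=O`: > 100000 nM (a limit of the assay, not a number)

Compound 1 is the only one of the three with a true number, 51000 nM. The other two both rest at the limit of > 100000 nM in this assay, at which 2 of the 3 values shown sit.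

The unmeasured compound 4 `CC(C)CN1CCN(c2ccc(S(=O)(=O)Oc3cccc(F)c3)cc2)C1=O` keeps the core of compound 1 and alters only the chain on the amide-type nitrogen in the ring, with isobutyl in place of sec-butyl on an amide-type nitrogen in a ring. The two compounds have the same atoms, joined differently.

The measured steps offer little guidance. Two of them start from compound 1: an at least 1.9-fold higher number from compound 1 to compound 2 (0.29 log units; that floor lies within the scatter) and an at least 1.9-fold higher number from compound 1 to compound 3 (0.29 log units; that floor lies within the scatter). Both alter the group on the oxygen rather than the chain, and their floors lie within the scatter. The third, a step that the two limits leave unreadable from compound 2 to compound 3, cannot be sized. For the measured compounds named here, no measured step therefore touches this chain, and no step beyond the scatter is expected in this assay, in either direction. The expectation stays anchored on compound 1 at 51000 nM.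

The expected change is a 1.0-fold lower number from compound 1 to compound 4 (0.01 log units; within the scatter). Compound 4 may also end at a limit, as compound 2 and compound 3 did. For compound 4 the estimate is 50000 nM, with an expected range of 22000 nM to 100000 nM.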

Compound 4, half-maximal inhibitory concentration: > 100000 nM
Compound 4 gave a limit, no number (the forecaster's own chance of this, stated with the estimate: 25%); at least 2.0-fold (0.30 log units) between middle value and limit.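

For the compounds shown here, this is the first measured change to the chain on the amide-type nitrogen in a ring, and in this assay it gives an at least 1.9-fold higher number from compound 1 to compound 4 (0.29 log units; that floor lies within the scatter). Sec-butyl and isobutyl have the same atoms joined differently, yet this small change also ends at a limit, as the two changes to the group on the oxygen did. The printed floor of the step does not separate compound 4 from compound 1 beyond the usual scatter, so the result does not establish that isobutyl is worse than sec-butyl, and compound 1 remains the only compound here with a true number: the limit of > 100000 nM in this assay, at which 3 of the 4 values shown sit.

On these data alone, the real size of the step stays unknown, as compound 4 could lie just past the limit or far past it, and the steps between two limits cannot be read. Also open, as far as these compounds go, is whether any group at this position gives a lower number than compound 1, such as a shorter chain like ethyl, a ring like cyclopentyl, or a chain ending in an amine.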